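Compound 3 and a single changed stereocentre

This account rests on a few compounds, and the source may have more. Where it says the series, first, only, none or still open, it means among the compounds named here.

In a functional assay on WiDr cells (Homo sapiens) for antiproliferative activity, with a stated time of 48 h (on this read-out higher numbers stand for weaker inhibition of growth and lower numbers for stronger inhibition of growth), compound 3 `C/C=C/[C@H]1C/C=C\C[C@@H](Cl)[C@@H](C[C@H](C=C=CBr)OC(C)=O)O1` gives no number, only the limit > 10 ug/mL. Compound 2 `C/C=C/[C@H]1C/C=C\C[C@@H](Cl)[C@@H](C[C@@H](O)C=C=CBr)O1` likewise gives only a limit, > 10 ug/mL. Compound 1 `COC(=O)/C=C\[C@H]1C[C@H]2O[C@@H](C[C@H]2Cl)[C@@H](Br)C[C@H]2O[C@@H]2[C@H](C)O1` also gives only a limit, > 10 ug/mL. Compound 4 `C/C=C/[C@H]1C/C=C\C[C@@H](Cl)[C@@H](C[C@@H](C=C=CBr)OC(C)=O)O1` differs from compound 3 in one way: the two compounds have the same atoms and bonds; at least one stereo element is drawn with a configuration in one of them and without one in the other: 1 of 8 stereo elements differ; a stereocentre at a saturated chain carbon is drawn R in compound 3 and S in compound 4. The only measured step among these close relatives is a step that the two limits leave unreadable from compound 2 to compound 3, so it offers no size to build on, and it does not touch this stereocentre. With compound 3 reported as the limit > 10 ug/mL, no change beyond the usual scatter is expected in this assay. The expected step is a step that the limit leaves unreadable from compound 3 to compound 4. For compound 4 the estimated value is 15 ug/mL, with an expected range from 8 ug/mL to 40 ug/mL, and a reported limit is the likeliest result.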

Compound 4, concentration for 50% growth inhibition: > 10 ug/mL
Compound 4 gave a limit, no number; the forecaster's own chance of this, stated with the estimate: 85%; the middle value lies beyond the limit too.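

Going by these compounds alone, compound 3 and compound 4 each give only a limit, not a number, and no step between them can be read. The compounds shown leave open whether the configuration at this saturated chain carbon affects growth inhibition in this assay.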